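The source may report more compounds than this note shows. Statements on the series, on what has been measured and on what is new or still open speak of the compounds shown alone.

Three compounds share one core. In a functional assay on DU-145 cells (Homo sapiens) for inhibition, read by trypan blue exclusion, with a stated time of 96 h (a higher number here means a weaker inhibitor of growth, a lower number a stronger inhibitor of growth), compound 1 `O=C(/C(=C\c1ccc(Cl)cc1)Sc1ccc(Cl)cc1)c1ccc(Cl)cc1` gives 1000 nM. Compound 2 `Cc1ccc(CS/C(=C/c2cc(Cl)cc(Cl)c2)C(=O)c2ccc(Cl)cc2)cc1` gives 10000 nM in this assay, and compound 3 `Cc1ccc(CS/C(=C/c2sccc2C)C(=O)c2ccc(Cl)cc2)cc1` gives 10000 nM. Compound 3 thus stands level with compound 2, the pair together forming the highest numbers of the three, while compound 1 sits well below both.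

Compound 4 `Cc1ccc(CS/C(=C/c2ccc(Cl)cc2)C(=O)c2ccc(Cl)cc2)cc1` differs from compound 3 in one place: 4-chlorophenyl in place of 3-methylthiophen-2-yl on a double-bonded chain carbon bound to a double-bonded chain carbon. Among the compounds with values here, the one comparable step, no change at the digits printed from compound 2 to compound 3 (within the scatter), concerned the same position and produced no change beyond the scatter, so a small step is expected here too. Compound 1, which carries 4-chlorophenyl at that position, gives a lower number, but it also differs elsewhere. Compound 4 is therefore expected to move by a 1.7-fold lower number from compound 3 to compound 4 (0.22 log units; within the scatter) in this assay, to an estimated 6000 nM, between 2000 nM and 20000 nM.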

Compound 4, concentration for 50% growth inhibition: 10000 nM
Compound 4: the middle estimate sits 1.7-fold (0.22 log units) below what was measured; the range from low to high includes it.
By their numbers in this assay, from the lowest: compound 1; then compounds 2, 3 and 4 (each within the scatter of the next).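

With 4-methylbenzyl on the sulfur, this assay shows no change at the digits printed from compound 3 to compound 4 (within the scatter) and no change at the digits printed from compound 2 to compound 4 (within the scatter), so 4-chlorophenyl on the double-bonded chain carbon does not stand apart from 3-methylthiophen-2-yl or 3,5-dichlorophenyl. The group on the sulfur can now be read alone: 4-methylbenzyl in place of 4-chlorophenyl there gives a 10-fold higher number from compound 1 to compound 4 (1.00 log units; beyond the scatter) in this assay. No measurement given here accounts for this difference.

Going by these compounds, whether an amine or a carboxylic acid on the double-bonded chain carbon would shift the number remains open. So does the effect of a longer chain on the sulfur.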